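Sulfonyl-linked hydroxamates: trimming the benzoyl methoxy groups

The source may hold more compounds than are shown below. What is called first, only, known or untested is meant among the compounds shown, and "the series" means these compounds.

Going by the values given here, compound 3 `COc1cc(C(=O)c2ccc3c(ccn3S(=O)(=O)c3cccc(/C=C/C(=O)NO)c3)c2)cc(OC)c1OC` sits second highest of the three numbers so far in an assay on isolated protein for inhibition of protein deacetylase HDAC6 (Homo sapiens) (a lower number here means a stronger inhibitor, a higher number a weaker inhibitor), where compound 3 gives 562 nM. Among the compounds with values here, its nearest neighbour is compound 1 `COc1cc(C(=O)c2ccc3c(ccn3S(=O)(=O)c3ccc(/C=C/C(=O)NO)cc3)c2)cc(OC)c1OC`, which in this assay gives 972 nM; the step of a 1.7-fold lower number from compound 1 to compound 3 (0.24 log units; within the scatter) is the only single-point change measured. Compound 2 `O=C(NO)c1ccc(Cn2ccc3cc(C(=O)c4ccc(F)cc4)ccc32)cc1` gives 9.25 nM, a number far removed from compound 3, but compound 2 differs from compound 3 in more than one place, so its value shows only that the series spans a wide range.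

Compound 4 `COc1ccc(C(=O)c2ccc3c(ccn3S(=O)(=O)c3cccc(/C=C/C(=O)NO)c3)c2)cc1` is the next member. The change from compound 3 is 4-methoxyphenyl in place of 3,4,5-trimethoxyphenyl on a carbonyl carbon. Within the data shown here, no measured step touches the benzoyl aryl group: the one step on record, from compound 1 to compound 3, concerns the position of the hydroxycarbamoyl ethenyl group on the sulfonyl aryl and stayed inside the scatter. There is therefore no basis for expecting a directional shift, and the step of a 1.0-fold lower number from compound 3 to compound 4 (0.01 log units; within the scatter) is estimated as one that does not exceed the usual scatter. Compound 4 is expected to give 550 nM in this assay, with a range from 200 nM to 1500 nM that reflects the absence of any comparable measured change.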

Compound 4, half-maximal inhibitory concentration: 751 nM
For compound 4 the middle estimate is 1.4-fold (0.14 log units) below the measured one; the measured number falls inside the stated range.
By their numbers in this assay, from the lowest: compound 2; then compounds 3, 4 and 1 (each within the scatter of the next).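

Going by these compounds alone, on a carbonyl carbon, 4-methoxyphenyl in place of 3,4,5-trimethoxyphenyl is the first measured change at this aryl group, and in this assay it reads as a 1.3-fold higher number from compound 3 to compound 4 (0.13 log units; within the scatter) and so leaves compound 3 and compound 4 indistinguishable. The group that enters has fewer heavy atoms and fewer hydrogen-bond acceptors than the group that leaves, so on this pair a sizeable trim of the methoxy groups produces no readable shift in this assay at this position. Nothing on hand offers a reason for this result.

Still open, as far as these compounds go, is whether any replacement on this aryl group can move the number beyond the scatter, for instance a carboxylic acid or a dimethylamino group in place of the methoxy group of 4-methoxyphenyl. Within the data shown here, the sulfonyl compounds also have no single-place step to compound 2 , and the place behind the value of 9.25 nM for compound 2 stays unassigned.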